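Replacing the phosphate ester of compound 1 with a carbamoyl group

The compounds below may be only part of what the source reports. "The series", "measured", "known", "first", "only" and "open" are said of these compounds alone.

Compound 1, with structure `CCOc1cc(NC(=O)C2(NC(=O)c3ccc4c(C5CCCC5)c(-c5ncc(Cl)cn5)n(C)c4c3)CCC2)ccc1/C=C/C(=O)OCOP(=O)(O)O`, is the weakest survivor of the three measured compounds. In an ADME assay (liver) for pharmacokinetics, with Liver microsome (Rattus norvegicus) as the target, using microsomes (a higher number here means that the compound lasts longer, a lower number that the compound disappears faster), compound 1 gives 0.15 h. Compound 2 `CCOc1cc(NC(=O)C2(NC(=O)c3ccc4c(C5CCCC5)c(-c5ncc(Cl)cn5)n(C)c4c3)CCC2)ccc1/C=C/C(=O)OCC(C)C` gives 1.42 h in this assay, and compound 3 `CCOc1cc(NC(=O)C2(NC(=O)c3ccc4c(C5CCCC5)c(-c5ncc(Cl)cn5)n(C)c4c3)CCC2)ccc1/C=C/C(=O)OCCOc1ccccc1` gives 16.5 h, so compound 1 stands lowest, with the step of a 9.5-fold higher number from compound 1 to compound 2 (0.98 log units; beyond the scatter) and the larger step of a 110-fold higher number from compound 1 to compound 3 (2.04 log units; beyond the scatter).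

Compound 4 `CCCN(C)C(=O)COC(=O)/C=C/c1ccc(NC(=O)C2(NC(=O)c3ccc4c(C5CCCC5)c(-c5ncc(Cl)cn5)n(C)c4c3)CCC2)cc1OCC` differs from compound 1 at the same place as both of these: a group of 7 heavy atoms (5 carbon, 1 nitrogen, 1 oxygen; no ring) in place of a group of 5 heavy atoms (4 oxygen, 1 phosphorus; no ring), on a saturated chain carbon bound to an oxygen next to a carbonyl group. The two measured steps at that position both point upward, from a modest rise in a 9.5-fold higher number from compound 1 to compound 2 (0.98 log units; beyond the scatter) to a large one in a 110-fold higher number from compound 1 to compound 3 (2.04 log units; beyond the scatter). The entering methyl(propyl)carbamoyl group matches neither isopropyl nor phenoxymethyl, so the size of the rise is uncertain, but a step beyond the scatter, in the upward direction, is expected, roughly a 13-fold higher number from compound 1 to compound 4 (1.12 log units; beyond the scatter).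

Compound 4 is therefore estimated at 2 h in this assay, with a range from 0.5 h to 8 h.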

Compound 4, half-life: 0.317 h
The estimate for compound 4 lay 6.3-fold (0.80 log units) above the measured number; measured number outside the range, below it.
By their numbers in this assay, from the lowest: compound 1; then compound 4; then compound 2; then compound 3.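

At this position, the replacement need not bring a large gain: in this assay the methyl(propyl)carbamoyl group gives only a 2.1-fold higher number from compound 1 to compound 4 (0.32 log units; beyond the scatter), still a rise beyond the scatter. The same group falls short of both earlier replacements, with a 4.5-fold lower number from compound 2 to compound 4 (0.65 log units; beyond the scatter) and a 52-fold lower number from compound 3 to compound 4 (1.72 log units; beyond the scatter), so the three replacements now span a wide range and all stay above compound 1, while having more heavy atoms than isopropyl does not by itself bring a higher number. Nothing available explains why this group sits so low.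

The compounds shown leave open whether the low number belongs to the carbamoyl itself or to the methyl and propyl it carries. A morpholine amide or a benzyl group at this place would help to separate those possibilities.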